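Adding a Second Chloro to Compound 3

The source may report more compounds than this note shows. Statements on the series, on what has been measured and on what is new or still open speak of the compounds shown alone.

Three compounds share one core and differ only in the aryl group on the amide-type nitrogen. In a functional assay on MDA-MB-231 cells (Homo sapiens) for cytotoxicity, read by MTT assay, with a stated time of 72 h (a lower number here means a stronger inhibitor, a higher number a weaker inhibitor), compound 1 `CN(C)CCCNc1nc(-c2ccc(NC(=O)Nc3ccc(F)cc3)cc2)nc2c(Cl)c(Cl)sc12` gives 980 nM. Compound 2 `CN(C)CCCNc1nc(-c2ccc(NC(=O)Nc3ccc(Cl)cc3)cc2)nc2c(Cl)c(Cl)sc12` gives 1160 nM in this assay, and compound 3 `CN(C)CCCNc1nc(-c2ccc(NC(=O)Nc3ccccc3Cl)cc2)nc2c(Cl)c(Cl)sc12` gives 1560 nM. Compound 3 thus holds the highest of the three numbers, yet every step among them stays within the scatter: a 1.2-fold higher number from compound 1 to compound 2 (0.07 log units; within the scatter), a 1.6-fold higher number from compound 1 to compound 3 (0.20 log units; within the scatter) and a 1.3-fold higher number from compound 2 to compound 3 (0.13 log units; within the scatter). Compound 4 `CN(C)CCCNc1nc(-c2ccc(NC(=O)Nc3ccc(Cl)cc3Cl)cc2)nc2c(Cl)c(Cl)sc12` differs from compound 3 by chloro in place of hydrogen on an aromatic carbon, so that the 2-chlorophenyl becomes 2,4-dichlorophenyl. For the measured compounds named here, no measured step adds a chloro to a ring that already carries one; the nearest comparisons are the halogen exchanges behind the steps above, all within the scatter. On that footing no step beyond the scatter is expected in this assay. The estimate for compound 4 is therefore 1500 nM, between 700 nM and 3500 nM, which amounts to an expected step of a 1.0-fold lower number from compound 3 to compound 4 (0.02 log units; within the scatter).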

Compound 4, half-maximal inhibitory concentration: 3490 nM
The estimate for compound 4 lay 2.3-fold (0.37 log units) below the measured number, within the range that was stated.
By their numbers in this assay, from the lowest: compounds 1, 2 and 3 (each within the scatter of the next); then compound 4.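

In this assay, for the compounds shown here, chloro in place of hydrogen on an aromatic carbon, para to a large group and meta to a chloro group, is the first change here to go beyond the scatter (a 2.2-fold higher number from compound 3 to compound 4 (0.35 log units; beyond the scatter)). The 2,4-dichlorophenyl group also stands apart from the 4-substituted rings, with a 3.0-fold higher number from compound 2 to compound 4 (0.48 log units; beyond the scatter) and a 3.6-fold higher number from compound 1 to compound 4 (0.55 log units; beyond the scatter), all modest steps, whereas the halogen exchanges among compounds 1, 2 and 3 stayed within the scatter. No supporting measurement bears on why the number rises with this second chloro.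

The compounds shown leave open whether this rise is specific to chloro or would also follow a methyl, methoxy or fluoro group at the same place on the 2-chlorophenyl ring. They also leave open whether a 2,4-difluorophenyl group would step the same way.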